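Series notes: amide substituent and solubility at neutral pH

The compounds below may be only part of what the source reports. "The series", "measured", "known", "first", "only" and "open" are said of these compounds alone.

Of the compounds shown here, three have been measured in a physicochemical assay for solubility, at pH 7; on this read-out lower numbers stand for lower solubility and higher numbers for higher solubility. Compound 1 `CN1CCN(c2ccc(C(=O)Nc3n[nH]c4cc(C(=O)NC(C)(C)c5ccccc5)sc34)cc2)CC1` gives 2000 nM; compound 2 `CN1CCN(c2ccc(C(=O)Nc3n[nH]c4cc(C(=O)Nc5ccccc5)sc34)cc2)CC1` gives 6000 nM; compound 3 `CC(C)NC(=O)c1cc2[nH]nc(NC(=O)c3ccc(N4CCN(C)CC4)cc3)c2s1` gives 59000 nM. Compound 2 thus stands second highest of the three numbers, with compound 1 at a lower number and compound 3 at a higher one.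

Compound 4 `CN1CCN(c2ccc(C(=O)Nc3n[nH]c4cc(C(=O)NCc5ccccc5)sc34)cc2)CC1` has not yet been measured. It differs from compound 2 by benzyl in place of phenyl on an amide-type nitrogen. Two measured steps alter the group on the same amide-type nitrogen: a 3.0-fold higher number from compound 1 to compound 2 (0.48 log units; beyond the scatter) and a 9.8-fold higher number from compound 2 to compound 3 (0.99 log units; beyond the scatter). Each swaps one carbon-only substituent for another, and the number moved modestly in both. Benzyl is none of phenyl, isopropyl or 1-methyl-1-phenylethyl, so those steps fix the size but not the direction of the change here. A step of modest size is expected for a 1.2-fold lower number from compound 2 to compound 4 (0.08 log units; within the scatter), possibly within the scatter. Compound 4 is therefore estimated at 5000 nM in this assay, with a range from 2000 nM to 12000 nM.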

Compound 4, solubility: 8000 nM
Estimate against measurement, compound 4: 1.6-fold (0.20 log units) below, and the stated range covers the measured number.
By their numbers in this assay, from the lowest: compound 1; then compounds 2 and 4 (each within the scatter of the next); then compound 3.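

Benzyl in place of phenyl on the amide-type nitrogen gives a 1.3-fold higher number from compound 2 to compound 4 (0.12 log units; within the scatter) in this assay, so compound 2 and compound 4 cannot be told apart on this read-out, and here the phenylcarbamoyl to benzylcarbamoyl change has no readable result. The other two steps, a 7.4-fold lower number from compound 3 to compound 4 (0.87 log units; beyond the scatter) and a 4.0-fold higher number from compound 1 to compound 4 (0.60 log units; beyond the scatter), lie beyond the scatter, which leaves compound 3, with isopropyl, highest of the four and compound 1, with 1-methyl-1-phenylethyl, lowest. Nothing measured at hand gives a cause for any of these steps.

Open, on these data alone, is whether a longer chain ending in phenyl on this nitrogen would stay level with compound 2 and compound 4. Also open, as far as these compounds go, is where an amine or a carboxylic acid on the same nitrogen substituent would fall relative to compound 3.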